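Chain extension on the butanoyl-bearing analogue

The compounds below may be only part of what the source reports. "The series", "measured", "known", "first", "only" and "open" are said of these compounds alone.

Measured in an assay on cell membranes for displacement of a labelled ligand from Sigma non-opioid intracellular receptor 1 (Rattus norvegicus); on this read-out lower numbers stand for stronger inhibition and higher numbers for weaker inhibition:
compound 1 `O=c1sc2ccccc2n1CCCCCCN1CCCCCC1` gives 7.5 nM
compound 2 `CCCC(=O)c1ccc2c(c1)sc(=O)n2CCCCCN1CCCCCC1` gives 16.3 nM

Compound 2 stands at the higher of the two numbers; compound 1 sits lower by a margin beyond the scatter. Compound 3 `CCCC(=O)c1ccc2c(c1)sc(=O)n2CCCCCCN1CCCCCC1` carries (azepan-1-yl)methyl in place of azepan-1-yl on a saturated chain carbon, five bonds along the chain from an aromatic nitrogen. For the measured compounds named here, no single-place step between measured compounds is known; the only guide is the chain length that compound 3 shares with compound 1, and compound 1 gives 7.5 nM. A step toward a lower number is expected, of about a 1.8-fold lower number from compound 2 to compound 3 (0.26 log units; within the scatter), close to the edge of the scatter. Compound 3 is estimated at 9 nM, with a range from 4 nM to 20 nM.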

Compound 3, inhibition constant: 10.8 nM
Compound 3: the middle estimate sits 1.2-fold (0.08 log units) below what was measured; measured number inside the range.
By their numbers in this assay, from the lowest: compounds 1, 3 and 2 (each within the scatter of the next, the first and the last beyond it).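

In this assay the change to (azepan-1-yl)methyl from azepan-1-yl on the saturated chain carbon gives a 1.5-fold lower number from compound 2 to compound 3 (0.18 log units; within the scatter) and so does not separate compound 2 from compound 3. Propylcarbonyl in place of hydrogen on an aromatic carbon gives a 1.4-fold higher number from compound 1 to compound 3 (0.16 log units; within the scatter) and, at this chain length, does not separate compound 1 from compound 3 either. No evidence bears on a cause for either step.

On these data alone, it remains open whether a longer chain than in compound 3, or piperidine in place of azepane, would shift the number beyond the scatter.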